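Two chlorines on the sulfonyl ring of compound 3

This account rests on a few compounds, and the source may have more. Where it says the series, first, only, none or still open, it means among the compounds named here.

Compound 3 `O=S(=O)(Nc1ccc(-c2nc3ccccc3o2)cc1)c1ccccc1Cl` is one of three sulfonamides sharing the same core, all tested in an ADME assay on HEK293 cells (Homo sapiens) for cytotoxicity, read by resazurin assay, with a stated time of 48 h; a lower number here means that less compound is tolerated, a higher number that more compound is tolerated. In this assay compound 3 gives > 100000 nM, which is a limit of the assay and not a number. Compound 2 `O=S(=O)(Nc1ccc(-c2nc3ccccc3o2)cc1)c1ccccc1C(F)(F)F` in this assay also gives a limit, > 100000 nM. Compound 1 `Cc1ccccc1S(=O)(=O)Nc1ccc2oc(-c3ccccc3)nc2c1` in this assay gives 57000 nM. Within the data shown here, the only single-change step among the measured compounds, a step that the two limits leave unreadable from compound 2 to compound 3, cannot be read in size because of the limit of > 100000 nM in this assay, at which 2 of the 3 values shown sit. So compound 3 stands at the limit, and no measured step shows whether changing the sulfonyl ring moves the read-out at all.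

Compound 4 `O=S(=O)(Nc1ccc(-c2nc3ccccc3o2)cc1)c1ccc(Cl)c(Cl)c1`, not yet measured, differs from compound 3 in this way: 3,4-dichlorophenyl in place of 2-chlorophenyl on a sulfonyl sulfur. Among the measured compounds shown here, no measured step bears on adding a second chlorine or shifting the chlorine to new positions on this ring, so no direction can be argued; for compound 4 the expected step of an at least 1.1-fold lower number from compound 3 to compound 4 (0.04 log units; that floor lies within the scatter) is none beyond the scatter. Compound 4 is therefore estimated at 90000 nM, within 35000 nM to 200000 nM.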

Compound 4, half-maximal cytotoxic concentration: > 100000 nM
Compound 4 was reported as a limit; the forecaster's own chance of this, stated with the estimate: 55%; middle value at least 1.1-fold (0.04 log units) from the limit.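

No step can be read between compound 3 and compound 4, because both are reported in this assay as limits and not as numbers: the limit of > 100000 nM in this assay, at which 3 of the 4 values shown sit. The compounds shown leave open whether any change on the sulfonyl ring moves the read-out at all.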